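The source may hold more compounds than are shown below. What is called first, only, known or untested is meant among the compounds shown, and "the series" means these compounds.

In a functional assay on MDA-MB-231 cells (Homo sapiens) for antiproliferative activity, read by MTT assay, with a stated time of 72 h (on this read-out lower numbers stand for stronger inhibition and higher numbers for weaker inhibition), compound 1 `CC1=CC[C@H]2[C@H](CC[C@]2(C)O)C(C)(C)[C@@H]1CC[C@H]1[C@]2(C)CC[C@H](OC(=O)c3ccccc3)C(C)(C)O[C@H]2CC[C@@]1(C)O` gives 16100 nM, compound 2 `CC1=CC[C@H]2[C@H](CC[C@]2(C)O)C(C)(C)[C@@H]1CC[C@H]1[C@]2(C)CC[C@H](OC(=O)c3ccc(Cl)cc3)C(C)(C)O[C@H]2CC[C@@]1(C)O` gives 10300 nM and compound 3 `CC1=CC[C@H]2[C@H](CC[C@]2(C)O)C(C)(C)[C@@H]1CC[C@H]1[C@]2(C)CC[C@H](OC(=O)c3ccc([N+](=O)[O-])cc3)C(C)(C)O[C@H]2CC[C@@]1(C)O` gives 8900 nM, so compound 3 stands within the scatter of both others. Compound 4 `CC1=CC[C@H]2[C@H](CC[C@]2(C)O)C(C)(C)[C@@H]1CC[C@H]1[C@]2(C)CC[C@H](OC(=O)c3ccccc3Cl)C(C)(C)O[C@H]2CC[C@@]1(C)O` differs from compound 3 by one change: 2-chlorophenyl in place of 4-nitrophenyl on a carbonyl carbon, which puts 2-chlorophenyl in place of 4-nitrophenyl on a carbonyl carbon. Within the data shown here, no measured compound carries 2-chlorophenyl, so the evidence is indirect. Among the measured compounds shown here, the steps that bear on it are a 1.6-fold lower number from compound 1 to compound 2 (0.19 log units; within the scatter), a 1.8-fold lower number from compound 1 to compound 3 (0.26 log units; within the scatter) and a 1.2-fold lower number from compound 2 to compound 3 (0.06 log units; within the scatter), and all of them are small. No step beyond the scatter is therefore expected in this assay, and the expected change is a 1.2-fold higher number from compound 3 to compound 4 (0.09 log units; within the scatter). The estimate for compound 4 is 11000 nM, with an expected range of 6000 nM to 20000 nM.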

Compound 4, half-maximal inhibitory concentration: 24300 nM
Compound 4: middle estimate off by 2.2-fold (0.34 log units), on the low side, and the stated range ends below it.
By their numbers in this assay, from the lowest: compounds 3, 2, 1 and 4 (each within the scatter of the next, the first and the last beyond it).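

In this assay, among these compounds, the two chlorophenyl groups give a 2.4-fold higher number from compound 2 to compound 4 (0.37 log units; beyond the scatter), so the place of the chloro on the aromatic ring matters here, which the earlier compounds could not show. The change from 4-nitrophenyl gives a 2.7-fold higher number from compound 3 to compound 4 (0.44 log units; beyond the scatter), also beyond the scatter, whereas chloro in place of hydrogen gives a 1.5-fold higher number from compound 1 to compound 4 (0.18 log units; within the scatter), within it. Nothing available explains why the two chlorophenyl groups differ. From the compounds shown here alone, whether an amine or a methoxy group on the aromatic ring would fall with 2-chlorophenyl or with 4-chlorophenyl remains open.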